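Methoxy to hydroxy on the pyrazole aryl of compound 3

This account rests on a few compounds, and the source may have more. Where it says the series, first, only, none or still open, it means among the compounds named here.

Measured so far in a functional assay on NCI-H522 cells (Homo sapiens) for inhibition, read by sulforhodamine B assay, with a stated time of 48 h; a higher number here means a weaker inhibitor of growth, a lower number a stronger inhibitor of growth:
compound 1 `O=C(Nc1cccc(-n2cc(-c3ccncc3)c(-c3ccc(Cl)c(O)c3)n2)c1)Nc1cccc(C(F)(F)F)c1` 1460 nM
compound 2 `O=C(Nc1cccc(-n2cc(-c3ccncc3)c(-c3ccc(Cl)c(O)c3)n2)c1)Nc1ccc(Cl)c(Cl)c1` 1190 nM
compound 3 `COc1cc(-c2nn(-c3cccc(NC(=O)Nc4ccc(Cl)c(C(F)(F)F)c4)c3)cc2-c2ccncc2)ccc1Cl` 1140 nM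

Compound 3 gives the lowest of the three numbers, but its gaps to compound 2 and compound 1 lie within the scatter, so no order among them can be claimed. Compound 4 `O=C(Nc1cccc(-n2cc(-c3ccncc3)c(-c3ccc(Cl)c(O)c3)n2)c1)Nc1ccc(Cl)c(C(F)(F)F)c1` differs from compound 3 by hydrogen in place of methyl on an oxygen on an aromatic ring. Among the measured compounds shown here, the only measured step, a 1.2-fold lower number from compound 1 to compound 2 (0.09 log units; within the scatter), concerns the aryl on the urea and does not bear on this change. Compound 1 and compound 2 already carry the 4-chloro-3-hydroxyphenyl group and sit within the scatter of compound 3, so no step beyond the scatter is expected. For compound 4 the estimate is 1200 nM, range 600 nM to 2500 nM, which means a 1.1-fold higher number from compound 3 to compound 4 (0.02 log units; within the scatter).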

Compound 4, concentration for 50% growth inhibition: 720 nM
Estimate against measurement, compound 4: 1.7-fold (0.22 log units) above; low and high end bracket the measured number.
By their numbers in this assay, from the lowest: compounds 4, 3, 2 and 1 (each within the scatter of the next, the first and the last beyond it).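

In this assay, hydroxy in place of methoxy on the 4-chloro-3-methoxyphenyl group gives a 1.6-fold lower number from compound 3 to compound 4 (0.20 log units; within the scatter), so this oxygen tolerates the loss of its methyl without a step beyond the scatter. Among the compounds shown here, with the 4-chloro-3-hydroxyphenyl group held, trifluoromethyl in place of chloro gives a 1.7-fold lower number from compound 2 to compound 4 (0.22 log units; within the scatter), while chloro in place of hydrogen gives a 2.0-fold lower number from compound 1 to compound 4 (0.31 log units; beyond the scatter), the only step here beyond the scatter. No measurement bears on the cause of these steps.

Open, on these data alone, is how an amine or a carboxylic acid in place of hydroxy would read in this assay. Also open, as far as these compounds go, is whether the chloro step holds with methoxy on this oxygen.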